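Cytotoxicity notes: removing the ethyl from the series core

This account rests on a few compounds, and the source may have more. Where it says the series, first, only, none or still open, it means among the compounds named here.

In an ADME assay on HEp-2 cells (Homo sapiens) for cytotoxicity, read by CCK-8 assay, with a stated time of 6 days (on this read-out higher numbers stand for lower toxicity in this test and lower numbers for higher toxicity in this test), compound 1 `Cc1ccc2nc(Cn3c(=O)n(C4CC4)c4ccncc43)c(CCCCO)n2c1` gives > 100000 nM, which is a limit of the assay rather than a number. Compound 2 `O=c1n(Cc2nc3ccc(F)cn3c2CCCCO)c2cnccc2n1C1CC1` gives in this assay > 100000 nM, again only a limit. Compound 3 `CCc1ccn2c(CCCCO)c(Cn3c(=O)n(C4CC4)c4ccncc43)nc2c1` likewise gives in this assay > 100000 nM, a limit. Among the compounds with values here, the one step between measured neighbours, a step that the two limits leave unreadable from compound 1 to compound 2, runs from one limit to another and its size cannot be read. Within the data shown here, compound 3 thus stands only at the limit shared by every value so far, (the limit of > 100000 nM in this assay, at which 3 of the 3 values shown sit). Compound 4 `O=c1n(Cc2nc3ccccn3c2CCCCO)c2cnccc2n1C1CC1` differs from compound 3 by hydrogen in place of ethyl on an aromatic carbon. Among the measured compounds shown here, no measured step covers a change of this kind, and the single measured step is itself unreadable, so no direction can be drawn from the steps; what the three values show is that each change made has left the read-out at the limit. Compound 4 is therefore expected to sit at the limit as well, an estimated 150000 nM with a range from 60000 nM to 400000 nM. The expected step that the limit leaves unreadable from compound 3 to compound 4 is accordingly no step beyond the scatter.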

Compound 4, half-maximal cytotoxic concentration: > 100000 nM
Compound 4 ended at the assay's limit (the forecaster's own chance of this, stated with the estimate: 85%); the middle value does not contradict the limit.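

The steps from compound 1, compound 2 and compound 3 to compound 4 cannot be read, and each value remains a limit of this assay: the limit of > 100000 nM in this assay, at which 4 of the 4 values shown sit.

The compounds shown leave open the true cytotoxic concentration of each compound and whether any of these aromatic-carbon changes alters it.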